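The compounds below may be only part of what the source reports. "The series", "measured", "known", "first", "only" and "open" are said of these compounds alone.

Measured compounds:
- compound 1 `Cc1cc2c(c(=O)[nH]1)OC(C(=O)CC(C)C)O2` in a functional assay on Jurkat cells (Homo sapiens) for cytotoxicity, read by WST assay, with a stated time of 48 h; on this read-out higher numbers stand for weaker inhibition and lower numbers for stronger inhibition: > 50000 nM
- compound 2 `CC1=CC(=O)[C@]2(O[C@@H]2C(=O)CC(C)C)C(=O)N1` in this assay: "not determined" (no result reported)

Among the measured compounds shown here, compound 1 is the only compound with an entry in this assay, and that entry is a limit, not a number: compound 1 gives > 50000 nM, so its potency is known only to lie beyond the edge of the assay (the limit of > 50000 nM in this assay, at which 1 of the 2 values shown sits). Compound 2, which shares the side chain but carries a different ring arrangement, has no result at all. For the measured compounds named here, no step between two measured compounds is therefore available, and the scatter cannot be checked from within this set.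

Compound 3 `CC(C)CC(=O)C1Oc2cc(Cc3ccccc3)[nH]c(=O)c2O1` differs from compound 1 by a single change: phenyl in place of hydrogen on a saturated chain carbon bound to an aromatic carbon. With compound 1 sitting at a limit, any step from compound 1 to compound 3 can only be read downward, into the measurable range, or not at all. The expected step of an at least 2.0-fold lower number from compound 1 to compound 3 (0.30 log units; that floor lies within the scatter) is modest, and compound 3 is estimated at 25000 nM, with a range from 4000 nM to 80000 nM.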

Compound 3, half-maximal inhibitory concentration: > 50000 nM
Compound 3 was reported as a limit; the forecaster's own chance of this, stated with the estimate: 50%; middle value at least 2.0-fold (0.30 log units) away from the limit.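

In this assay compound 3 gives > 50000 nM, which is a limit and not a number. Among the compounds shown here, compound 1 also stands at a limit, and no step from compound 1 to compound 3 can be read. On these data alone, how far past the limit either compound lies, and whether phenyl in place of hydrogen changes potency at all, remains open.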